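The source may report more compounds than this note shows. Statements on the series, on what has been measured and on what is new or still open speak of the compounds shown alone.

Measured compounds:
compound 1 `Cc1ccc2nc(Nc3nc(Nc4ccc(S(N)(=O)=O)cc4)ncc3F)sc2c1` gives 4960 nM in a functional assay on PC-3 cells (Homo sapiens) for antiproliferative activity, read by MTT assay, with a stated time of 48 h; on this read-out higher numbers stand for weaker inhibition and lower numbers for stronger inhibition;
compound 2 `Cc1ccc2nc(Nc3nc(Nc4ccc(S(N)(=O)=O)cc4)ncc3C)sc2c1` gives 2710 nM in this assay;
compound 3 `Cc1ccc2nc(Nc3ccnc(Nc4ccc(S(N)(=O)=O)cc4)n3)sc2c1` gives 1640 nM in this assay.

Compound 2 stands second highest of the three numbers. Its nearest neighbour is compound 3, the step of a 1.7-fold lower number from compound 2 to compound 3 (0.22 log units; within the scatter) lying within the scatter; its furthest is compound 1, the step of a 1.8-fold lower number from compound 1 to compound 2 (0.26 log units; within the scatter) also within the scatter. Within the data shown here, the only step that reaches beyond the scatter is a 3.0-fold lower number from compound 1 to compound 3 (0.48 log units; beyond the scatter), and it is modest.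

Compound 4 `Cc1cnc(Nc2ccc(S(N)(=O)=O)cc2)nc1Nc1nc2ccc(F)cc2s1` differs from compound 2 by fluoro in place of methyl on an aromatic carbon. All three measured steps exchange fluoro, methyl and hydrogen at one single site, and that site is not the one changed here: none of them touches the fused system of two rings. They do show that swapping fluoro and methyl at the site they do cover moves the number by no more than the scatter, a 1.8-fold lower number from compound 1 to compound 2 (0.26 log units; within the scatter). Without a measured step at the fused ring, the change from compound 2 to compound 4 is expected to stay within the scatter as well.

Compound 4 is therefore estimated at 2700 nM, with a range from 1200 nM to 6000 nM, an expected step of a 1.0-fold lower number from compound 2 to compound 4 (0.00 log units; within the scatter).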

Compound 4, half-maximal inhibitory concentration: 6980 nM
The estimate for compound 4 lay 2.6-fold (0.41 log units) below the measured number; the whole stated range lies below it.
By their numbers in this assay, from the lowest: compounds 3, 2, 1 and 4 (each within the scatter of the next, the first and the last beyond it).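

Among these compounds, in (this assay), the fused system of two rings is changed for the first time, and the exchange there, fluoro in place of methyl on an aromatic carbon of the six-membered aromatic ring of carbon only, gives a modest step beyond the scatter (a 2.6-fold higher number from compound 2 to compound 4 (0.41 log units; beyond the scatter)). Among the compounds shown here, the related exchange at the site covered by the earlier compounds, methyl in place of fluoro, stays within the scatter (a 1.8-fold lower number from compound 1 to compound 2 (0.26 log units; within the scatter)), so the step at that site does not carry over to the fused ring, and this ring position is one where a single-atom exchange can move the number beyond the scatter. No measurement available here bears on what lies behind this step.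

With only methyl and fluoro shown at this position, it remains open whether hydrogen, chloro, methoxy or an amine would follow either compound, so no trend across groups can be drawn from this one pair. From the compounds shown here alone, it also remains open whether the step at the fused ring would hold with fluoro or hydrogen at the other site in place of methyl.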